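Notes on an ethoxy substitution in the cytotoxicity series

The source may report more compounds than this note shows. Statements on the series, on what has been measured and on what is new or still open speak of the compounds shown alone.

Measured so far:
compound 1 `O=C(Nc1ccccc1)c1cccc(/C=C2\CC(=O)N(c3ccccc3)C2=O)c1` — > 100000 nM
compound 2 `CCc1cccc(NC(=O)c2cccc(/C=C3\CC(=O)N(Cc4ccccc4)C3=O)c2)c1` — 91500 nM
compound 3 `CCCCCN1C(=O)C/C(=C\c2cccc(C(=O)NCCCC)c2)C1=O` — > 100000 nM

In an ADME assay on SW480 cells (Homo sapiens) for cytotoxicity, read by MTT assay, with a stated time of 72 h (on this read-out lower numbers stand for stronger inhibition and higher numbers for weaker inhibition), compound 1 gives only a limit, > 100000 nM. Compound 3 likewise returns a limit, > 100000 nM. Compound 2 gives a number, 91500 nM. Two of the three values thus sit at the limit of > 100000 nM in this assay, at which 2 of the 3 values shown sit, and compound 1 stands at that limit rather than at a measured number. For the measured compounds named here, no pair of measured compounds differs in a single place, so no isolated step is available.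

Compound 4, `CCOc1ccc(NC(=O)c2cccc(/C=C3\CC(=O)N(c4ccccc4)C3=O)c2)cc1`, differs from compound 1 by ethoxy in place of hydrogen on an aromatic carbon. Going by the values given here, nothing among the measured compounds separates out such a change. Given that compound 1 sits at the limit of > 100000 nM in this assay, at which 2 of the 3 values shown sit, the step from compound 1 to compound 4 is expected to be none beyond the scatter, a number no higher from compound 1 to compound 4 (the limit leaves the size open). For compound 4 the estimated value is 100000 nM, with an expected range from 50000 nM to 200000 nM, and a fair chance that this assay again reports only a limit.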

Compound 4, half-maximal inhibitory concentration: 91500 nM
Estimate against measurement, compound 4: 1.1-fold (0.04 log units) above; measured number inside the range.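

In this assay, compound 4 returns a measured number, 91500 nM. Ethoxy in place of hydrogen on an aromatic carbon, para to a large group, therefore amounts to an at least 1.0-fold lower number from compound 1 to compound 4 (0.03 log units; that floor lies within the scatter), so this position tolerates the added group without any change shown beyond the scatter. The true size of the step stays unknown because compound 1 stands at a limit: the limit of > 100000 nM in this assay, at which 2 of the 4 values shown sit.

Open, going by these compounds, is whether a different group at this place, such as an amine, a carboxylic acid or a longer alkoxy chain, would bring a step beyond the scatter. Also open, on these data alone, is whether ethoxy at this place would give a readable step on a parent compound with a measured number rather than a limit.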